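Methoxy for Methyl Across Two Related Cores

A few compounds are considered here, and "the series" means these few. Any claim that something is new, unique, unknown or untested is made for them only; others in the source may bear on it.

Compound 1 `CC1=C(C(=O)Nc2ccc(C)cc2)C(c2cn(-c3ccccc3)nc2-c2ccc(Cl)cc2)NC(=O)N1` is measured in a functional assay on MCF7 cells (Homo sapiens) for inhibition, read by sulforhodamine B assay, with a stated time of 24 h (on this read-out higher numbers stand for weaker inhibition of growth and lower numbers for stronger inhibition of growth), at 69700 nM. Compound 2 `CC1=C(C(=O)Nc2ccc(C)cc2)C(c2cn(-c3ccccc3)nc2-c2ccc(Cl)cc2)NC(=S)N1` shares the outer parts of compound 1 but has a different core; the difference between the two cores is not broken down here. In this assay compound 2 gives 43500 nM, and set against compound 1 the two values fall within the usual scatter of this kind of measurement. Compound 3 `COc1ccc(NC(=O)C2=C(C)NC(=O)NC2c2cn(-c3ccccc3)nc2-c2ccc(Cl)cc2)cc1` is compound 1 with one change, (methoxy in place of methyl on an aromatic carbon), and in this assay compound 3 gives 69700 nM; the step of no change at the digits printed from compound 1 to compound 3 (within the scatter) leaves nothing to read beyond the scatter. Compound 4 `COc1ccc(NC(=O)C2=C(C)NC(=S)NC2c2cn(-c3ccccc3)nc2-c2ccc(Cl)cc2)cc1`, not yet measured, carries the same change on the core of compound 2: methoxy in place of methyl on an aromatic carbon. The place of the change reads the same in both pairs. Because no change at the digits printed from compound 1 to compound 3 (within the scatter) stayed within the scatter, the matching step on the core of compound 2 is expected to be of the same size, a 1.0-fold higher number from compound 2 to compound 4 (0.01 log units; within the scatter). On that basis compound 4 is expected at 45000 nM, with 22000 nM and 90000 nM as the expected range.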

Compound 4, concentration for 50% growth inhibition: 70000 nM
Estimate against measurement, compound 4: 1.6-fold (0.19 log units) below, and the stated range covers the measured number.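

The step on the core of compound 2 reads a 1.6-fold higher number from compound 2 to compound 4 (0.21 log units; within the scatter) in this assay. Set beside the step on the core of compound 1, it gives no sign that the two cores respond differently to methoxy in place of methyl on an aromatic carbon: the same change on two cores in this assay, no change at the digits printed (within the scatter) from compound 1 to compound 3 and a 1.6-fold higher number (0.21 log units; within the scatter) from compound 2 to compound 4, 1.6-fold (0.21 log units) apart, within the scatter of two such steps. This shows that the change carries from one core to the other without a readable difference in this one read-out, but it rests on two pairs and does not show that the change would behave alike on other cores, at another place on the ring or in another assay.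

Still open, from the compounds shown here alone, is whether a different group in place of the methyl or methoxy, such as an amine, a carboxylic acid or a longer chain, would produce a step beyond the scatter on either core. Also open, going by these compounds, is whether the two cores would still match if the chloro group elsewhere in these compounds were replaced by, for example, an amine.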